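A few compounds are considered here, and "the series" means these few. Any claim that something is new, unique, unknown or untested is made for them only; others in the source may bear on it.

Of the compounds shown here, three have been tested so far in a functional assay (Homo sapiens) for inhibition of Nucleic Acid, tested at 100 uM; a lower number here means less inhibition, a higher number more inhibition at the concentration tested (going by the name of the read-out). Compound 1 `Sc1[nH]ccc2ncnc1-2` gives 26%, compound 2 `OC[C@H]1OC(n2cnc3c(Nc4ccccc4)nccc32)[C@H](O)[C@@H]1O` gives 4%, and compound 3 `OCCNc1[nH]ccc2ncnc1-2` gives 3%. Compound 2 and compound 3 give numbers within the scatter of each other, while compound 1 gives a number higher than compound 2, beyond the scatter. Within the data shown here, the only measured step, a number 23 percentage points lower from compound 1 to compound 3 (beyond the scatter), is a different kind of change made on a different core, so it does not speak to the step at hand. Compound 4 `CCCCCCNc1nccc2c1ncn2C1O[C@H](CO)[C@@H](O)[C@H]1O` differs from compound 2 by hexyl in place of phenyl on a nitrogen on an aromatic ring. Among the measured compounds shown here, no measured step bears on this change, so no shift beyond the scatter is expected. The estimate for compound 4 in this assay is 6%, with a range from 0% to 20%. That estimate means an expected step of a number 2 percentage points higher from compound 2 to compound 4 (within the scatter).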

Compound 4, a percentage reported as inhibition, at one concentration (the size of the read-out at that concentration, not a potency): 8%
Compound 4: middle estimate off by 2 percentage points, on the low side; low and high end bracket the measured number.
By their numbers in this assay, from the lowest: compounds 3, 2 and 4 (each within the scatter of the next); then compound 1.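

Replacing the anilino group with hexylamino, a flat aromatic ring exchanged for an open chain, gives a number 4 percentage points higher from compound 2 to compound 4 (within the scatter). On this nitrogen on an aromatic ring, then, the read-out does not separate the phenyl ring from the hexyl chain, at least for this pair. Nothing available explains this result.

Still open, as far as these compounds go, is whether a different group on this nitrogen, such as a chain ending in a carboxylic acid or an amine, would shift the number beyond the scatter. It is also unknown whether the same swap would behave alike on another core.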